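The source may hold more compounds than are shown below. What is called first, only, known or untested is meant among the compounds shown, and "the series" means these compounds.

Measured compounds:
compound 1, `CC(C)CCOC(=O)NS(=O)(=O)c1sc(CC(C)C)cc1-c1cccc(Cn2ccnc2)c1`, in an assay on HEK293 cells for displacement of a labelled ligand from Type-2 angiotensin II receptor (Homo sapiens), read by scintillation counting, with a stated time of 240 min (on this read-out higher numbers stand for weaker inhibition and lower numbers for stronger inhibition), compound 1 gives 230 nM
compound 2, `CC(C)Cc1cc(-c2cccc(Cn3ccnc3)c2)c(S(=O)(=O)NC(=O)OC(C)(C)C)s1`, compound 2 gives 270 nM

Among the measured compounds shown here, compound 2 stands highest of these two numbers, and the one step to it, a 1.2-fold higher number from compound 1 to compound 2 (0.07 log units; within the scatter), lies within the scatter. Compound 3, `CC(C)Cc1cc(-c2cccc(Cn3ccnc3)c2)c(S(=O)(=O)NC(=O)OC2CCCC2)s1`, carries cyclopentyl in place of tert-butyl on an oxygen next to a carbonyl group. For the measured compounds named here, the only measured step touching that place is the exchange on the same oxygen, a 1.2-fold higher number from compound 1 to compound 2 (0.07 log units; within the scatter), which stayed within the scatter. The author therefore expects no step beyond the scatter in this assay, reading a 1.1-fold lower number from compound 2 to compound 3 (0.03 log units; within the scatter). Compound 3 is estimated at 250 nM, within a range of 110 nM to 560 nM.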

Compound 3, inhibition constant: 180 nM
Compound 3: the middle estimate sits 1.4-fold (0.14 log units) above what was measured; the range from low to high includes it.
By their numbers in this assay, from the lowest: compounds 3, 1 and 2 (each within the scatter of the next).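

In this assay, a ring on the oxygen next to a carbonyl group behaves no differently from the open groups: cyclopentyl in place of tert-butyl gives a 1.5-fold lower number from compound 2 to compound 3 (0.18 log units; within the scatter), and cyclopentyl in place of isopentyl gives a 1.3-fold lower number from compound 1 to compound 3 (0.11 log units; within the scatter). Tert-butyl, isopentyl and cyclopentyl therefore all read alike at this place, which the first two compounds could not show for a ring. No evidence is available on why these groups read alike. Still open, on these data alone, is whether an amine or a carboxylic acid on the chain at this oxygen, or a phenyl ring there, would give a step beyond the scatter.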